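The source may report more compounds than this note shows. Statements on the series, on what has been measured and on what is new or still open speak of the compounds shown alone.

Working notes on the hydroxyacyl series. Compound 1 `CC(C)(C)[C@@H](O)C(=O)N1[C@@H]2C[C@@H]2C[C@H]1C(=O)NCc1cc(Cl)ccc1-n1cnnn1` gives 1100 nM in a functional assay on a cell-free system (plasma, Homo sapiens), with a stated time of 3 min (a higher number here means a weaker inhibitor, a lower number a stronger inhibitor), the highest of the three numbers recorded. Compound 2 `COC(C)(C)[C@@H](O)C(=O)N1[C@H](C(=O)NCc2cc(Cl)ccc2-n2cnnn2)C[C@@H]2C[C@@H]21` gives 1000 nM in this assay, and compound 3 `CC1(C[C@@H](O)C(=O)N2N=CC[C@H]2C(=O)NCc2cc(Cl)ccc2-n2cnnn2)CC1` gives 730 nM; both gaps to compound 1 fall within the usual scatter, so no ordering among the three can be read. Going by the values given here, no step between measured compounds is available. Compound 4 `O=C(NCc1cc(Cl)ccc1-n1cnnn1)[C@@H]1C[C@H]2C[C@H]2N1C(=O)[C@H](O)c1cccc(F)c1` is the next candidate; relative to compound 1 the change is 3-fluorophenyl in place of tert-butyl on a saturated chain carbon bound to a carbonyl carbon and an oxygen on a saturated carbon. Among the compounds with values here, no measured step informs this change, so only a small shift, if any beyond the scatter, is expected, with slightly more weight on the lower side. Compound 4 is estimated at 750 nM in this assay, with a range of 200 nM to 2800 nM, a step of a 1.5-fold lower number from compound 1 to compound 4 (0.17 log units; within the scatter) expected.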

Compound 4, half-maximal inhibitory concentration: 1100 nM
Compound 4: middle estimate off by 1.5-fold (0.17 log units), on the low side, and the stated range covers the measured number.
By their numbers in this assay, from the lowest: compounds 3, 2, 1 and 4 (each within the scatter of the next).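

The step from tert-butyl to 3-fluorophenyl gives no change at the digits printed from compound 1 to compound 4 (within the scatter) in this assay. Going by these compounds alone, this is the first reading at this position: on the core of compound 1, a six-membered aromatic ring of carbon only, with 7 heavy atoms in place of 4, leaves the number within the scatter. Nothing measured here bears on why the number holds.

Going by these compounds, whether a primary amine or a carboxylic acid at this position would also leave the number within the scatter remains open. So does whether the 3-fluorophenyl result holds on the cores of compound 2 and compound 3.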